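Swapping Carbamoyl for Isopropyl on the Amide Side Chain

The compounds below may be only part of what the source reports. "The series", "measured", "known", "first", "only" and "open" are said of these compounds alone.

Three compounds have been measured in a functional assay on the whole organism (Tail, strain ICR) with Mus musculus as the target, in the tail flick test, with a stated time of 150 min, at a dose of 25 umol/kg by the oral route; a lower number here means a weaker effect, a higher number a stronger effect of the compound at the dose given:
compound 1 `NC(=O)CC[C@H](NC(=O)CN(c1ncnc2c1ncn2C1CCCCO1)C1CC1)C(=O)OCc1ccccc1` gives 10.7%
compound 2 `O=C(CN(c1ncnc2c1ncn2C1CCCCO1)C1CC1)NCC(=O)OCc1ccccc1` gives 7.26%
compound 3 `NC(=O)C[C@H](NC(=O)CN(c1ncnc2c1ncn2C1CCCCO1)C1CC1)C(=O)OCc1ccccc1` gives 21.7%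

Compound 3 stands highest of the three. The step of a number 11 percentage points higher from compound 1 to compound 3 (beyond the scatter) and the step of a number 14.4 percentage points higher from compound 2 to compound 3 (beyond the scatter) both lie beyond the scatter, so compound 3 is the most active of the measured set. The step of a number 3.4 percentage points lower from compound 1 to compound 2 (within the scatter) lies within the scatter, so compound 1 and compound 2 cannot be told apart.

Compound 4 `CC(C)C[C@H](NC(=O)CN(c1ncnc2c1ncn2C1CCCCO1)C1CC1)C(=O)OCc1ccccc1` has not yet been measured. It differs from compound 3 by isopropyl in place of carbamoyl on a saturated chain carbon, two bonds along the chain from an amide-type nitrogen and a carbonyl carbon. The measured steps that bear on this place are the two that lead to compound 3: shortening the chain by one carbon gave a modest gain, and adding the carbamoylmethyl onto the bare chain carbon gave a modest gain. Going by the values given here, no measured step removes the hydrogen-bond donor and acceptor altogether, as the change to isopropyl does, so the direction is uncertain. Among the compounds with values here, the steps so far are all modest in size, so a modest downward step is expected in this assay, with a fair chance of none beyond the scatter. Compound 4 is therefore estimated at 12%, between 3% and 22%, an expected step of a number 9.7 percentage points lower from compound 3 to compound 4 (within the scatter).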

Compound 4, a percentage reported as activity, at one dose (the size of the read-out at that dose, not a potency): 6.47%
For compound 4 the middle estimate is 5.5 percentage points above the measured one, within the range that was stated.
By their numbers in this assay, from the lowest: compounds 4, 2 and 1 (each within the scatter of the next); then compound 3.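

In this assay, isopropyl in place of carbamoyl gives a clear drop (a number 15.2 percentage points lower from compound 3 to compound 4 (beyond the scatter)). The two groups have the same count of heavy atoms, but isopropyl is all carbon and has no hydrogen-bond donor or acceptor, so matching the count of heavy atoms at this place does not keep the number of compound 3. The same result also shows that a side chain on this carbon is not enough by itself: the isobutyl of compound 4 cannot be told apart from the bare chain carbon of compound 2 (a number 0.8 percentage points lower from compound 2 to compound 4 (within the scatter)) or from the 2-carbamoylethyl of compound 1 (a number 4.2 percentage points lower from compound 1 to compound 4 (within the scatter)), and among these four compounds only the carbamoylmethyl of compound 3 stands apart.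

Nothing measured on these compounds explains why carbamoyl and isopropyl part in this way. From the compounds shown here alone, it also stays open whether the higher number of compound 3 needs the carbamoyl itself, or whether a carboxylic acid, a hydroxymethyl or an amine on the same chain carbon would give a similar reading.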